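Trifluoromethyl carbinol bearing a nitrile on the shared core

The source may hold more compounds than are shown below. What is called first, only, known or untested is meant among the compounds shown, and "the series" means these compounds.

Measured compounds:
Compound 1 `CC#C[C@H]1CN(S(=O)(=O)c2ccc(N)nc2)CCN1c1ccccc1` gives > 399 mL.min-1.g-1 in an ADME assay (liver) for metabolic stability, with Liver microsome (Rattus norvegicus) as the target, using microsomes and NADPH, with a stated time of 30 min (on this read-out lower numbers stand for slow clearance and higher numbers for fast clearance), a limit of that assay.
Compound 2 `CC#C[C@H]1CN(S(=O)(=O)c2ccc(N)nc2)CCN1c1ccc(S(=O)(=O)Nc2ccccc2)cc1` gives > 399 mL.min-1.g-1 in this assay, again a limit.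
Compound 3 `CC#CCC(O)(c1ccc(N2CCN(S(=O)(=O)c3ccc(N)nc3)C[C@@H]2C#CC)cc1)C(F)(F)F` gives 115 mL.min-1.g-1 in this assay.

Compound 1 stands at the limit of this assay, and only a limit is known for it; the limit of > 399 mL.min-1.g-1 in this assay, at which 2 of the 3 values shown sit, holds for compound 1 and compound 2 alike, so compound 1 cannot be ranked against compound 2. The step that the two limits leave unreadable from compound 1 to compound 2 is therefore unreadable. Against compound 3 the picture is clearer: an at least 3.4-fold lower number from compound 1 to compound 3 (0.54 log units; beyond the scatter), and an at least 3.4-fold lower number from compound 2 to compound 3 (0.54 log units; beyond the scatter).

Compound 4 `CC#C[C@H]1CN(S(=O)(=O)c2ccc(N)nc2)CCN1c1ccc(C(O)(CC#N)C(F)(F)F)cc1` carries the change (a group of 9 heavy atoms (4 carbon, 1 nitrogen, 1 oxygen, 3 fluorine; no ring) in place of a hydrogen atom, on an aromatic carbon). Within the data shown here, the group that enters resembles the one that enters in compound 3, sharing the trifluoromethyl carbinol and differing in that a nitrile replaces the triple-bonded carbon chain. The step from compound 1 to compound 3 is the one that bears on this change, and its size was at least modest in the direction of slower clearance. For compound 4 a step of similar direction is expected, an at least 2.6-fold lower number from compound 1 to compound 4 (0.42 log units; beyond the scatter), though compound 4 is not compound 3 and the number could still sit at the limit. The estimated value for compound 4 in this assay is 150 mL.min-1.g-1, with a range from 60 mL.min-1.g-1 to 399 mL.min-1.g-1.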

Compound 4, intrinsic clearance in microsomes: 57 mL.min-1.g-1
Compound 4: middle estimate off by 2.6-fold (0.42 log units), on the high side; measured number below the stated range.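

In this assay a second group at this aromatic carbon comes off the limit, with an at least 7.0-fold lower number from compound 1 to compound 4 (0.84 log units; beyond the scatter) and an at least 7.0-fold lower number from compound 2 to compound 4 (0.84 log units; beyond the scatter), so among the compounds shown the lower clearance is no longer tied to the single side chain of compound 3. On the chain itself, cyano in place of prop-1-yn-1-yl gives a 2.0-fold lower number from compound 3 to compound 4 (0.30 log units; within the scatter), and compound 3 and compound 4 cannot be told apart on this read-out. Compound 2, with phenylsulfamoyl on the same carbon, goes against any rule that a large group here is enough, and the steps from compound 1 and compound 2 give only a lower bound on their size: the limit of > 399 mL.min-1.g-1 in this assay, at which 2 of the 4 values shown sit.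

On these data alone, the trifluoromethyl and the hydroxyl always occur together in compound 3 and compound 4, so it remains open which of them carries the step, a question that a carbinol with methyl in place of trifluoromethyl, or a methyl ether in place of the hydroxyl, would address. Also open, as far as these compounds go, is how the chain end behaves beyond these two groups, for instance with an amine, a carboxylic acid or a longer chain.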